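The source may hold more compounds than are shown below. What is called first, only, known or untested is meant among the compounds shown, and "the series" means these compounds.

Working notes on the series. The shared core is that of compound 1 `COc1ccc(-c2cc(-c3ccc(OC)cc3)on2)cc1`. In a functional assay on MCF7 cells (Homo sapiens) for antiproliferative activity, read by cell counting, with a stated time of 5 days (a higher number here means a weaker inhibitor, a lower number a stronger inhibitor), compound 1 gives > 100000 nM, which is a limit of the assay and not a number. Compound 2 `CCc1c(-c2ccc(OC)cc2)noc1-c1ccc(OC)cc1` carries ethyl in place of hydrogen on an aromatic carbon. In this assay compound 2 gives > 100000 nM, again a limit rather than a number. Going by the values given here, the single measured step in the set is a step that the two limits leave unreadable from compound 1 to compound 2. Both recorded values sit at the limit of > 100000 nM in this assay, at which 2 of the 2 values shown sit, so compound 1 stands at the limit itself, with no numbered value anywhere in the set against which to place it.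

Compound 3 `COc1ccc(-c2cc(-c3ccc([N+](=O)[O-])cc3)on2)cc1` differs from compound 1 by nitro in place of methoxy on an aromatic carbon. Among the compounds with values here, no measured step covers this change; the one step that exists concerns an ethyl for hydrogen exchange and is unreadable between two limits, so it offers no size and no direction to carry over. The default is therefore that compound 3 stays near the limit, with a modest allowance for a numbered value either way.

For compound 3 in this assay the expected value is 100000 nM, within 20000 nM to 300000 nM, most likely again reported as a limit. For compound 3 this means an expected step of a number no higher from compound 1 to compound 3 (the limit leaves the size open).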

Compound 3, half-maximal inhibitory concentration: > 100000 nM
Compound 3 was reported as a limit; the forecaster's own chance of this, stated with the estimate: 70%; the middle value sits exactly at the limit.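

In this assay compound 3 gives > 100000 nM as a limit and not a number. No step can be read between compound 1 and compound 3, as each value shown is a limit: the limit of > 100000 nM in this assay, at which 3 of the 3 values shown sit.

The compounds shown leave open whether any change to the shared core gives a numbered value in this assay at all.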